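Swapping cyano for ethoxycarbonyl on a weak inhibitor

The source may hold more compounds than are shown below. What is called first, only, known or untested is meant among the compounds shown, and "the series" means these compounds.

Compound 1 `N#Cc1c(/N=C/c2ccccc2)sc2c1CCCC2` gives 10 nM
Compound 2 `N#Cc1c(/N=C/NNc2ccccc2)sc2c1CCCC2` gives 30 nM
Compound 3 `N#Cc1c(/N=C/n2nc(N)cc2O)sc2c1CCCC2` gives 80 nM

All three numbers come from a functional assay on NCI-H460 cells (Homo sapiens) for inhibition (a higher number here means a weaker inhibitor, a lower number a stronger inhibitor), and are the concentrations needed for half-maximal inhibition. Compound 3 is the weakest inhibitor of the three at 80 nM and its gaps to compound 2 and to compound 1 both lie beyond the usual scatter of repeated measurements.

The next molecule is compound 4 `CCOC(=O)c1c(/N=C/n2nc(N)cc2O)sc2c1CCCC2` which has not yet been measured. It keeps everything in compound 3 except for one group, with ethoxycarbonyl in place of cyano on an aromatic carbon. The new group is larger and brings no ring or charge.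

Going by the values given here, compound 1, compound 2 and compound 3 all carry cyano, so no measured pair shows what this exchange does. The estimate therefore stays anchored on compound 3 at 80 nM and leans only slightly towards a weaker number. The expected result is a 1.3-fold higher number from compound 3 to compound 4 (0.10 log units; within the scatter) in this assay with no change beyond the scatter, although the uncertainty is wide. Compound 4 is estimated at about 100 nM with an expected range from 30 nM to 350 nM in the coming measurement.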

Compound 4, half-maximal inhibitory concentration: 20 nM
Compound 4: the middle estimate sits 5.0-fold (0.70 log units) above what was measured, and the stated range ends above it.
By their numbers in this assay, from the lowest: compounds 1, 4 and 2 (each within the scatter of the next, the first and the last beyond it); then compound 3.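

In this assay, putting ethoxycarbonyl in place of cyano gives a 4.0-fold lower number from compound 3 to compound 4 (0.60 log units; beyond the scatter). Going by these compounds alone, this is the first view of what this position does, since compound 1, compound 2 and compound 3 all carry cyano there, and it shows that the number responds to the group on this aromatic carbon and that the cyano is not required for inhibition in this pair: with the rest of the molecule unchanged, a group of 5 heavy atoms replaces one of 2, and the inhibitor becomes stronger rather than weaker. Nothing at hand explains why the number falls, so the step records an outcome and not a mechanism.

The compounds shown leave open which part of ethoxycarbonyl matters, a question that a carboxylic acid, a primary amide or methoxycarbonyl at the same position would help to answer. They also leave open whether the same exchange would lower the number when the rest of the molecule is that of compound 1 or compound 2, since this single pair speaks only for the side chain shared by compound 3 and compound 4.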